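The compounds below may be only part of what the source reports. "The series", "measured", "known", "first", "only" and "open" are said of these compounds alone.

Measured so far:
Compound 1, `Cc1cc(O)c(C2=NN(c3ccc(S(N)(=O)=O)cc3)C(c3ccccc3O)C2)cc1Cl`: 2660 nM
Compound 2, `Cc1cc(O)c(C2=NN(c3ccc(S(N)(=O)=O)cc3)C(c3ccccc3Cl)C2)cc1Cl`: 1750 nM
Compound 3, `Cc1cc(O)c(C2=NN(c3ccc(S(N)(=O)=O)cc3)C(/C=C/c3ccccc3)C2)cc1Cl`: 3930 nM

All three numbers come from a functional assay on MCF7 cells (Homo sapiens) for antiproliferative activity, with a stated time of 48 h; on this read-out lower numbers stand for stronger inhibition of growth and higher numbers for weaker inhibition of growth. Among them compound 3 gives the highest number; the gap to compound 1 lies within the scatter, the gap to compound 2 lies beyond it.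

The next compound is compound 4, `COc1ccc(C2CC(c3cc(Cl)c(C)cc3O)=NN2c2ccc(S(N)(=O)=O)cc2)cc1OC`, which has not yet been measured. It differs from compound 3 in one place: 3,4-dimethoxyphenyl in place of 2-phenylethenyl on a saturated ring carbon. Among the compounds with values here, two measured steps touch this same carbon, since compounds 1 and 2 each carry a different aromatic group there while compound 3 carries the 2-phenylethenyl group. a 1.5-fold higher number from compound 1 to compound 3 (0.17 log units; within the scatter) a 2.2-fold higher number from compound 2 to compound 3 (0.35 log units; beyond the scatter) Both steps point the same way, one staying within the scatter and the other going modestly beyond it. Within the data shown here, exchanging the 2-phenylethenyl group for an aromatic group again, as in compound 4, is therefore expected to bring the number back toward those of compounds 1 and 2, though the 3,4-dimethoxyphenyl group itself has no measured precedent here. For compound 4 the expected result is a 1.8-fold lower number from compound 3 to compound 4 (0.25 log units; within the scatter). Compound 4 is accordingly estimated at 2200 nM, with a range from 900 nM to 5500 nM.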

Compound 4, concentration for 50% growth inhibition: 3070 nM
Compound 4: middle estimate off by 1.4-fold (0.14 log units), on the low side; the measured number falls inside the stated range.
By their numbers in this assay, from the lowest: compounds 2, 1, 4 and 3 (each within the scatter of the next, the first and the last beyond it).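

In this assay the 3,4-dimethoxyphenyl group on this saturated ring carbon lies within the scatter of all three earlier groups (a 1.3-fold lower number from compound 3 to compound 4 (0.11 log units; within the scatter); a 1.8-fold higher number from compound 2 to compound 4 (0.24 log units; within the scatter); a 1.2-fold higher number from compound 1 to compound 4 (0.06 log units; within the scatter)). The earlier compounds had shown one modest gap at this carbon, between the 2-chlorophenyl group and the 2-phenylethenyl group, and compound 4 sits within the scatter of both ends of that gap, so the gap is not divided into separate levels by this new compound. This position therefore tolerates a group with 2 hydrogen-bond acceptors and more heavy atoms than 2-phenylethenyl without a change that can be told from the scatter, and nothing available explains this result.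

All the groups shown at this carbon are built around a six-membered aromatic ring of carbon only, so it stays open what a small methyl group, an aminomethyl group or a carboxylic acid would do here. On these data alone, it is also open how a plain phenyl or a 4-methoxyphenyl group would compare, which would show whether either methoxy group matters on its own.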